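The source may hold more compounds than are shown below. What is called first, only, known or untested is meant among the compounds shown, and "the series" means these compounds.

For the measured compounds named here, compound 2 `COc1ccc(-c2nn(-c3ccccc3)cc2C(=O)Nc2nc3ccc(Cl)cc3s2)cc1` stands at one end of the two numbers measured so far in a functional assay on HT-29 cells (Homo sapiens) for cytotoxicity, read by MTT assay, with a stated time of 72 h (a lower number here means a stronger inhibitor, a higher number a weaker inhibitor), where compound 2 gives 6570 nM. Compound 1 `COc1ccc(-c2nn(-c3ccccc3)cc2C(=O)Nc2nc3ccc(F)cc3s2)cc1` gives 5560 nM in this assay, and the step of a 1.2-fold higher number from compound 1 to compound 2 (0.07 log units; within the scatter) lies within the scatter. Compound 3 `COc1ccc(-c2nn(-c3ccccc3)cc2C(=O)Nc2nc3ccc(C)cc3s2)cc1` differs from compound 2 in one place: methyl in place of chloro on an aromatic carbon. Going by the values given here, no measured step swaps chloro for methyl; the only step known, a 1.2-fold higher number from compound 1 to compound 2 (0.07 log units; within the scatter), bears on it and shows a swap at that aromatic carbon changing little. The expected step is therefore a 1.1-fold lower number from compound 2 to compound 3 (0.04 log units; within the scatter), within the scatter. The estimate for compound 3 is 6000 nM, between 3000 nM and 12000 nM.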

Compound 3, half-maximal inhibitory concentration: 21500 nM
Compound 3: the middle estimate sits 3.6-fold (0.55 log units) below what was measured; the measured number lies above the stated range.
By their numbers in this assay, from the lowest: compounds 1 and 2 (each within the scatter of the next); then compound 3.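

Methyl in place of chloro gives a 3.3-fold higher number from compound 2 to compound 3 (0.51 log units; beyond the scatter) and methyl in place of fluoro gives a 3.9-fold higher number from compound 1 to compound 3 (0.59 log units; beyond the scatter) at this aromatic carbon, so this position does respond to the group placed on it. Chloro and fluoro remain within the scatter of each other, while methyl, which like them adds a single heavy atom, gives the weakest inhibitor of the three. No measurement shown here explains this difference.

On these data alone, it remains open whether an amine, a nitrile or a longer chain such as propyl at this carbon would match the halogens or methyl, or differ from both.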